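Removing the Propyl Group from Compound 2

This account rests on a few compounds, and the source may have more. Where it says the series, first, only, none or still open, it means among the compounds named here.

In a functional assay on DU-145 cells (Homo sapiens) for inhibition, read by trypan blue exclusion, with a stated time of 72 h (a higher number here means a weaker inhibitor, a lower number a stronger inhibitor), compound 2 (`CCCn1c(=O)c(S(=O)(=O)c2ccc(F)cc2F)cc2cnc(Nc3ccc4[nH]ccc4c3)nc21`) gives 1000 nM and compound 3 (`Cn1ccc2cc(Nc3ncc4cc(S(=O)(=O)c5ccc(F)cc5F)c(=O)n(C)c4n3)ccc21`) gives 750 nM as a close pair, since these two numbers lie within the usual scatter of each other. Compound 1 (`COc1ccc(Nc2ncc3cc(S(=O)(=O)c4ccc(C)cc4)c(=O)n(C)c3n2)cc1`) gives 100000 nM as a far higher number, beyond the scatter from compound 2.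

The change from compound 2 to compound 4 (`O=c1[nH]c2nc(Nc3ccc4[nH]ccc4c3)ncc2cc1S(=O)(=O)c1ccc(F)cc1F`) is hydrogen in place of propyl on an aromatic nitrogen and in words it puts hydrogen in place of propyl on an aromatic nitrogen. Going by the values given here, no measured compound carries hydrogen on that nitrogen, so the data offer no direct guide. Compound 3 at 750 nM carries methyl there and differs elsewhere too, while compound 2 at 1000 nM carries propyl, and these values do not separate the two groups. A modest rise in the number, meaning a weaker inhibitor, is expected, and the estimated size is a 2.5-fold higher number from compound 2 to compound 4 (0.40 log units; beyond the scatter) with wide uncertainty. The expected value for compound 4 is 2500 nM with an estimated range from 500 nM to 20000 nM as the likely span.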

Compound 4, half-maximal inhibitory concentration: 15000 nM
Compound 4: the middle estimate sits 6.0-fold (0.78 log units) below what was measured; low and high end bracket the measured number.
By their numbers in this assay, from the lowest: compounds 3 and 2 (each within the scatter of the next); then compound 4; then compound 1.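

Removing the propyl group from the aromatic nitrogen gives a 15-fold higher number from compound 2 to compound 4 (1.18 log units; beyond the scatter) in this assay, so this position does not tolerate every change: with the rest of the molecule unchanged, propyl goes with a clearly stronger inhibitor than hydrogen. The earlier compounds shown here could not show this, as none carried hydrogen on that nitrogen and no two of them differed in this place alone. No evidence at hand explains the size of this loss.

On these data alone, it remains open whether any group on this nitrogen would restore the activity of compound 2 or whether the length of the chain matters, as an ethyl group, a longer chain such as butyl, or a propyl chain ending in an amine could show. Compound 3 carries methyl there but also differs elsewhere, so it cannot settle this.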